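Swapping chloro for methoxy on a weak growth inhibitor

The source may hold more compounds than are shown below. What is called first, only, known or untested is meant among the compounds shown, and "the series" means these compounds.

Among the compounds with values here, in a functional assay on HT-29 cells (Homo sapiens) for cytotoxicity, read by MTT assay, with a stated time of 72 h (a lower number here means a stronger inhibitor of growth, a higher number a weaker inhibitor of growth), compound 1 `N#C/C(=C/c1ccc(Cl)cc1)C(=O)c1ccc[nH]1` gives 54000 nM, the only exact number so far and the weakest result of the three compounds tested. Compound 2 `N#C/C(=C/c1ccc([N+](=O)[O-])cc1)C(=O)c1ccc[nH]1` gives < 10000 nM, which is a limit of the assay and not a number. Compound 3 `N#C/C(=C/c1ccc(Cl)c(Cl)c1)C(=O)c1ccc[nH]1` gives < 10000 nM, which is also a limit.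

The next compound, compound 4 `COc1ccc(/C=C(/C#N)C(=O)c2ccc[nH]2)cc1`, has methoxy in place of chloro on an aromatic carbon. Two measured changes made at the same part of the molecule offer some guidance. Nitro in place of chloro gives an at least 5.4-fold lower number from compound 1 to compound 2 (0.73 log units; beyond the scatter), and chloro in place of hydrogen gives an at least 5.4-fold lower number from compound 1 to compound 3 (0.73 log units; beyond the scatter). Both moved this assay toward stronger inhibition, but neither introduced methoxy, so they are only a loose guide. A modest shift in the same direction therefore seems reasonable, and the expected change is a 2.2-fold lower number from compound 1 to compound 4 (0.33 log units; beyond the scatter). For compound 4 the estimated value is 25000 nM, with an expected range from 7000 nM to 80000 nM.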

Compound 4, concentration for 50% growth inhibition: < 10000 nM
Compound 4 ended at the assay's limit; the forecaster's own chance of this, stated with the estimate: 40%; at least 2.5-fold (0.39 log units) between middle value and limit.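

At this place on the ring, para to a large group, methoxy in place of chloro gives in this assay an at least 5.4-fold lower number from compound 1 to compound 4 (0.73 log units; beyond the scatter). The value of compound 4 is a limit of the assay and not a number. Nitro in compound 2 and methoxy in compound 4 are thus two different replacements of this chloro that both reach the limit, although compound 3 reaches it while keeping the chloro, so losing the chloro is not the only route there, and the step between compound 2 and compound 4 cannot be read because both values are limits: the limit of < 10000 nM in this assay, at which 3 of the 4 values shown sit.

From the compounds shown here alone, how an amine, a carboxylic acid or a longer chain at this place would compare with the chloro of compound 1 remains open. Any order between nitro and methoxy also remains open.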